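The source may hold more compounds than are shown below. What is called first, only, known or untested is meant among the compounds shown, and "the series" means these compounds.

Measured so far in a functional assay on the whole organism (strain albino) for inhibition, with Rattus norvegicus as the target, read by paw edema, with stated times of 1 h and 3 h, at a dose of 100 mg/kg by the oral route; a lower number here means a weaker effect, a higher number a stronger effect of the compound at the dose given:

- compound 1 `O=C(CSc1nc(-c2ccc(O)cc2)c(C(=O)O)c(=O)[nH]1)Nn1c(COc2ccc(Cl)cc2Cl)nc2ccccc2c1=O` gives 38.6%
- compound 2 `N#Cc1c(Cl)nc(SCC(=O)Nn2c(COc3ccc(Cl)cc3Cl)nc3ccccc3c2=O)nc1-c1ccccc1` gives 68.4%
- compound 3 `N#Cc1c(Cl)nc(SCC(=O)Nn2c(COc3ccc(Cl)cc3Cl)nc3ccccc3c2=O)nc1-c1ccc(O)cc1` gives 73.7%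

Compound 2 stands second highest of the three numbers. Its nearest neighbour is compound 3, separated by a number 5.3 percentage points higher from compound 2 to compound 3 (within the scatter), so the two are not distinguishable. Within the data shown here, compound 1 lies furthest from it, with a lower number beyond the scatter; no single-point step connects compound 1 to compound 2.

Compound 4 `N#Cc1c(Nc2ccc(O)cc2)nc(SCC(=O)Nn2c(COc3ccc(Cl)cc3Cl)nc3ccccc3c2=O)nc1-c1ccccc1` is not yet measured. It differs from compound 2 by (4-hydroxyphenyl)amino in place of chloro on an aromatic carbon. Among the measured compounds shown here, the one measured step, a number 5.3 percentage points higher from compound 2 to compound 3 (within the scatter), concerns a different group at a different place and so bears on this change only indirectly; it shows that a small change left the read-out within the scatter. There is no measured exchange of the chloro group at this place, so the expectation rests on compound 2 alone. No step beyond the scatter is expected in either direction.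

For compound 4 the estimated value in this assay is 70%, within a range from 55% to 85%. The expected step of a number 1.6 percentage points higher from compound 2 to compound 4 (within the scatter) would lie within the scatter.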

Compound 4, a percentage reported as inhibition, in the whole organism at one dose (the size of the read-out at that dose, not a potency): 59.7%
For compound 4 the middle estimate is 10.3 percentage points above the measured one; the measured number falls inside the stated range.
By their numbers in this assay, from the lowest: compound 1; then compounds 4, 2 and 3 (each within the scatter of the next, the first and the last beyond it).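

In this assay, among these compounds, the first exchange read at this position gives a number 8.7 percentage points lower from compound 2 to compound 4 (within the scatter) and so adds what the earlier compounds could not show: a change at the chloro place itself. On this aromatic carbon, next to the ring nitrogen and ortho to a cyano group, chloro can give way to (4-hydroxyphenyl)amino, with 8 heavy atoms, a six-membered aromatic ring and 2 hydrogen-bond donors, without a step beyond the scatter at the single dose given. Nothing available bears on why an exchange of this size leaves the read-out within the scatter.

The compounds shown leave open how a small group at this place, such as an unsubstituted amine or a methoxy group, would read. Also open, on these data alone, is how plain phenylamino, without the hydroxy, would compare with (4-hydroxyphenyl)amino here.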